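Mouse liver clearance notes: compound 1 to compound 4

The source may hold more compounds than are shown below. What is called first, only, known or untested is meant among the compounds shown, and "the series" means these compounds.

Measured so far:
compound 1, `COc1cc([C@](O)(CCN(C)C)[C@@H](c2cc3cc(Br)ccc3nc2OC)c2cccc(OC)c2F)cc(OC(C)C)n1`, 6 uL/min
compound 2, `COc1cc([C@](O)(CCN(C)C)[C@@H](c2cc3cc(Br)ccc3nc2OC)c2ccnc(OC)c2OC)cc(OC(C)C)n1`, 6.7 uL/min
compound 3, `CCOc1cc([C@](O)(CCN(C)C)[C@@H](c2cc3cc(Br)ccc3nc2OC)c2c(OC)cncc2OC)cc(OC(C)C)n1`, 2.3 uL/min

All three numbers come from an ADME assay on microsomes from liver (Mus musculus) for metabolic stability; a higher number here means faster removal of the compound, a lower number slower removal. Compound 1 stands second highest of the three: compound 2 sits within the scatter of it, while compound 3 lies beyond the scatter on the lower side. Within the data shown here, the only single-change step in the set, a 1.1-fold higher number from compound 1 to compound 2 (0.05 log units; within the scatter), is within the scatter. Compound 3 differs from compound 1 in two places, so that gap is not read as one step.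

Compound 4, `CCSc1cc([C@](O)(CCN(C)C)[C@@H](c2cc3cc(Br)ccc3nc2OC)c2cccc(OC)c2F)cc(SCC)n1`, is not yet measured in this assay. It differs from compound 1 as follows: a group of 12 heavy atoms (9 carbon, 1 nitrogen, 2 sulfur; one six-membered aromatic ring with 1 hetero atom) in place of a group of 12 heavy atoms (9 carbon, 1 nitrogen, 2 oxygen; one six-membered aromatic ring with 1 hetero atom), on a saturated chain carbon bound to an oxygen on a saturated carbon and two saturated chain carbons. Among the measured compounds shown here, no measured step covers a change at this place, and none replaces oxygen with sulfur anywhere in the shared core; the step between compound 1 and compound 2 concerns a different position and offers no guide to the size expected here. With nothing to anchor a direction, the expected number for compound 4 is close to that of compound 1, carrying a wide range, and the step is estimated as a 1.3-fold higher number from compound 1 to compound 4 (0.12 log units; within the scatter). The estimate for compound 4 in this assay is 8 uL/min, within the range 3 uL/min to 22 uL/min.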

Compound 4, intrinsic clearance in a liver preparation (reported as CLH), per the amount of preparation that the assay uses: 12 uL/min
Compound 4: the middle estimate sits 1.5-fold (0.18 log units) below what was measured; the measured number falls inside the stated range.
By their numbers in this assay, from the lowest: compound 3; then compounds 1, 2 and 4 (each within the scatter of the next).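

In this assay, among these compounds, the group holding 2 sulfur atoms in place of the group holding 2 oxygen atoms, on a saturated chain carbon bound to an oxygen on a saturated carbon and two saturated chain carbons, gives a 2.0-fold higher number from compound 1 to compound 4 (0.30 log units; within the scatter); this is the first reading of any change at this place, and the heavy-atom, hydrogen-bond donor and hydrogen-bond acceptor counts stay the same across it. With a 1.1-fold higher number from compound 1 to compound 2 (0.05 log units; within the scatter) at a different place, the two single-change steps now available both lie within the scatter, so neither place has yet shown a change beyond it. No measurement is available that could explain the step from compound 1 to compound 4.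

Both oxygen atoms give way to sulfur together in this change, and the ends of the two groups also differ, so the compounds shown cannot assign the step to any one part of the group. As far as these compounds go, how this assay responds at the same place to a group carrying an amine, a carboxylic acid or a longer chain remains open, as does a group holding one sulfur and one oxygen.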